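Chloro-for-hydrogen step on the fused core, M14 cytotoxicity

The compounds below may be only part of what the source reports. "The series", "measured", "known", "first", "only" and "open" are said of these compounds alone.

Measured so far:
compound 1 `ClCc1cccc(Cn2cnc3ncnc(Cl)c32)c1` gives 67600 nM
compound 2 `ClCc1cccc(Cn2cnc3c(Cl)ncnc32)c1` gives 6600 nM
compound 3 `ClCc1ccc(Cn2cnc3nc(Cl)nc(Cl)c32)cc1` gives 6910 nM

All three numbers come from a functional assay on M14 cells (Homo sapiens) for cytotoxicity, read by sulforhodamine B assay, with a stated time of 48 h; a higher number here means that more compound is tolerated, a lower number that less compound is tolerated. Compound 2 stands at the lowest value of the three; compound 3 lies within the scatter of it, while compound 1 lies beyond the scatter on the higher side. Compound 4 `ClCc1cccc(Cn2cnc3c(Cl)nc(Cl)nc32)c1` differs from compound 2 by chloro in place of hydrogen on an aromatic carbon. Among the compounds with values here, no measured pair in this set isolates that single change. Compound 3, which carries two chloro groups on its core, sits close to compound 2, so no shift beyond the scatter is expected in this assay. For compound 4 the expected value is 6000 nM, with a range from 2500 nM to 15000 nM. The step from compound 2 to compound 4 is therefore estimated as a 1.1-fold lower number from compound 2 to compound 4 (0.04 log units; within the scatter).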

Compound 4, concentration lethal to 50% of the cells: 6450 nM
For compound 4 the middle estimate is 1.1-fold (0.03 log units) below the measured one; the range from low to high includes it.
By their numbers in this assay, from the lowest: compounds 4, 2 and 3 (each within the scatter of the next); then compound 1.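

In this assay, within the data shown here, a 1.0-fold lower number from compound 2 to compound 4 (0.01 log units; within the scatter) is the first step to isolate a single change: chloro in place of hydrogen on an aromatic carbon between two ring nitrogen atoms. At this position, with the rest of compound 2 kept, the chloro group leaves the number within the scatter. No measurement available here bears on the reason for this.

As far as these compounds go, whether an amine or a methoxy group at this position would also leave the number within the scatter stays open. From the compounds shown here alone, whether the same step holds on the core of compound 1 also stays open.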